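A few compounds are considered here, and "the series" means these few. Any claim that something is new, unique, unknown or untested is made for them only; others in the source may bear on it.

Measured compounds:
Compound 1 `Cn1nc2c(=O)n(CC3(O)CCN(Cc4ccc(-c5n[nH]c(=O)o5)cc4Cl)CC3)cnc2c1-c1ccc(CN)cc1` gives 171 nM in an assay on isolated protein for inhibition of ubiquitin carboxyl-terminal hydrolase 7 (Homo sapiens), with stated times of 30 min and 2 h; a higher number here means a weaker inhibitor, a lower number a stronger inhibitor.
Compound 2 `Cn1nc2c(=O)n(CC3(O)CCN(Cc4ccc(-c5ccco5)cc4Cl)CC3)cnc2c1-c1ccc(CNCCO)cc1` gives 8.2 nM in this assay.
Compound 3 `Cn1nc2c(=O)n(CC3(O)CCN(Cc4ccc(-c5ccco5)cc4Cl)CC3)cnc2c1-c1ccc(OC(F)F)cc1` gives 179 nM in this assay.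

Compound 1 stands second highest of the three numbers; its number is within the scatter of compound 3 and far above compound 2. Compound 4 `Cn1nc2c(=O)n(CC3(O)CCN(Cc4ccc(-c5cccs5)cc4Cl)CC3)cnc2c1-c1ccc(CN)cc1` has not yet been measured. It differs from compound 1 at one place: a group of 5 heavy atoms (4 carbon, 1 sulfur; one five-membered aromatic ring with 1 hetero atom) in place of a group of 6 heavy atoms (2 carbon, 2 nitrogen, 2 oxygen; one five-membered aromatic ring with 3 hetero atoms), on an aromatic carbon.

Among the measured compounds shown here, the only measured step, a 22-fold higher number from compound 2 to compound 3 (1.34 log units; beyond the scatter), changes a different part of the molecule, so no measured step bears directly on the change from compound 1 to compound 4. What compounds 2 and 3 show is that the shared core carrying a five-membered ring with one oxygen at the same place can reach a low number when paired with an aminomethyl-type group, as in compound 2. Compound 1 carries such an aminomethyl group, so the thiophen-2-yl is expected to bring compound 4 nearer to compound 2, a step of a 6.8-fold lower number from compound 1 to compound 4 (0.84 log units; beyond the scatter).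

Compound 4 is therefore estimated at 25 nM, expected to fall between 6 nM and 100 nM.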

Compound 4, half-maximal inhibitory concentration: 38.6 nM
The estimate for compound 4 lay 1.5-fold (0.19 log units) below the measured number; measured number inside the range.
By their numbers in this assay, from the lowest: compound 2; then compound 4; then compounds 1 and 3 (each within the scatter of the next).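

Among the compounds shown here, this is the first direct reading at this position, an aromatic carbon meta to a chloro group and para to a large group. With the rest of the molecule unchanged, thiophen-2-yl in place of the ring with three hetero atoms gives a 4.4-fold lower number from compound 1 to compound 4 (0.65 log units; beyond the scatter) in this assay, so the group placed here clearly affects the number. Nothing measured here explains the shift, and this single pair cannot separate the contributions of the ring atoms, the hydrogen-bond donor and the acceptors.

Going by these compounds, it remains open how furan-2-yl would compare with thiophen-2-yl when the aminomethyl group of compound 4 is kept unchanged. Also open, on these data alone, are how a phenyl ring or a carboxylic acid would behave at this position, and whether thiophen-2-yl gives a similar step alongside ((2-hydroxyethyl)amino)methyl.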